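This account rests on a few compounds, and the source may have more. Where it says the series, first, only, none or still open, it means among the compounds named here.

Compound 1 `NS(=O)(=O)NCC1CCN(c2cc(-c3ccccc3)ncn2)CC1` and compound 2 `Cc1ccc(-c2cc(N3CCC(CNS(N)(=O)=O)CC3)ncn2)cc1` share one core and differ in a single spot. In a functional assay on M21 cells (Homo sapiens) for antiproliferative activity, read by sulforhodamine B assay, with a stated time of 48 h (a lower number here means a stronger inhibitor of growth, a higher number a weaker inhibitor of growth), compound 1 gives > 100000 nM, which is a limit of the assay rather than a number. In this assay compound 2 gives 71000 nM. The change between them is methyl in place of hydrogen on an aromatic carbon, and the step is an at least 1.4-fold lower number from compound 1 to compound 2 (0.14 log units; that floor lies within the scatter). Compound 2 therefore holds the only real number in this series; the other value is a limit, as shown by the limit of > 100000 nM in this assay, at which 1 of the 2 values shown sits.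

Compound 3 `CCCCc1ccc(-c2cc(N3CCC(CNS(N)(=O)=O)CC3)ncn2)cc1` extends that methyl: the difference is propyl in place of hydrogen on a saturated chain carbon bound to an aromatic carbon. For the measured compounds named here, the only measured step that bears on this change is the one from compound 1 to compound 2, and its floor lies within the scatter, so it gives no firm direction. Growing the chain on the same aromatic position is expected to move the number little, with a modest chance of a somewhat lower value. Compound 3 is therefore expected to give 45000 nM in this assay, with a range from 12000 nM to 150000 nM. The step this estimate implies is expected to be a 1.6-fold lower number from compound 2 to compound 3 (0.20 log units; within the scatter).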

Compound 3, concentration for 50% growth inhibition: 47200 nM
Compound 3: middle estimate off by 1.0-fold (0.02 log units), on the low side; low and high end bracket the measured number.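

Moving from methyl to butyl at this aromatic position does not clearly change growth inhibition in this assay, since the step (a 1.5-fold lower number from compound 2 to compound 3 (0.18 log units; within the scatter)) stays within the scatter, so the added propyl has no effect that these numbers can separate from noise. The new information comes from comparing butyl with hydrogen on the aromatic carbon: this change gives a step (an at least 2.1-fold lower number from compound 1 to compound 3 (0.32 log units; beyond the scatter)) that clears the scatter, which the methyl step alone could not do, so a substituent at this position can be linked to a lower number once it is a butyl group. As far as these compounds go, the true size of that step remains unknown, and the printed figure is only a floor because the value of compound 1 is a limit of the assay and not a number: the limit of > 100000 nM in this assay, at which 1 of the 3 values shown sits.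

From the compounds shown here alone, it remains open whether a longer chain, such as hexyl, would lower the number further or whether the effect levels off at butyl. It is equally unclear how an amine or a carboxylic acid at the end of the chain would compare with the plain carbon chain of compound 3.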